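A few compounds are considered here, and "the series" means these few. Any claim that something is new, unique, unknown or untested is made for them only; others in the source may bear on it.

Compound 1 `CCCOC(=O)Nc1ccc(S(=O)(=O)N2C[C@H](c3ccccc3)NC2=O)cc1CC` gives 60 nM in a functional assay on HCT-116 cells (Homo sapiens) for cytotoxicity, read by MTT assay; on this read-out higher numbers stand for weaker inhibition and lower numbers for stronger inhibition.
Compound 2 `CCOC(=O)Nc1ccc(S(=O)(=O)N2C[C@H](c3ccccc3)NC2=O)cc1C` gives 70 nM.
Compound 3 `CCOC(=O)Nc1ccc(S(=O)(=O)N2C[C@H](c3ccccc3)NC2=O)c(C)c1C` gives 350 nM.

Compound 2 stands second highest of the three numbers; its gap to compound 1 lies within the scatter, while compound 3 sits well above it. Among the compounds with values here, the only counted step is a 5.0-fold higher number from compound 2 to compound 3 (0.70 log units; beyond the scatter), a methyl added on an aromatic carbon. Compound 4 `CCOC(=O)Nc1ccc(S(=O)(=O)N2C[C@H](c3ccccc3)NC2=O)cc1F` differs from compound 2 by fluoro in place of methyl on an aromatic carbon. Within the data shown here, no measured step swaps methyl for fluoro, so the single step bears only loosely on it; an added methyl weakened compound 3, but here one small group replaces another of the same size. A change within the scatter is therefore expected, a 1.3-fold higher number from compound 2 to compound 4 (0.11 log units; within the scatter). Compound 4 is estimated at 90 nM, in the range 35 nM to 250 nM.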

Compound 4, half-maximal inhibitory concentration: 5000 nM
Compound 4: middle estimate off by 56-fold (1.74 log units), on the low side; measured number outside the range, above it.
By their numbers in this assay, from the lowest: compounds 1 and 2 (each within the scatter of the next); then compound 3; then compound 4.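

At this position, ortho to the (ethoxycarbonyl)amino group, exchanging one heavy atom for another costs far more than the equal atom count suggests: the change gives a 71-fold higher number from compound 2 to compound 4 (1.85 log units; beyond the scatter), a much weaker inhibition. The earlier step, a 5.0-fold higher number from compound 2 to compound 3 (0.70 log units; beyond the scatter), was only modest and showed the effect of adding a methyl, whereas this result shows that replacing the methyl already present can matter much more. No measured evidence here explains the loss.

Going by these compounds, whether a chloro, methoxy or amine group at this position would keep the inhibition of compound 2 or lose it like the fluoro remains open. So does the result of leaving only hydrogen there.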